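A few compounds are considered here, and "the series" means these few. Any claim that something is new, unique, unknown or untested is made for them only; others in the source may bear on it.

Measured so far in a functional assay on MCF7 cells (Homo sapiens) for antiproliferative activity, read by MTT assay, with a stated time of 72 h; a higher number here means a weaker inhibitor, a lower number a stronger inhibitor:
Compound 1 `COc1cccc(N2C(=O)COc3ccc(-c4cnc(Cl)c(NS(=O)(=O)c5ccc(F)cc5)c4)cc32)c1`: > 40000 nM, a limit of the assay and not a number
Compound 2 `Cc1ccc(N2C(=O)COc3ccc(-c4cnc(Cl)c(NS(=O)(=O)c5ccc(F)cc5)c4)cc32)cc1`: 32600 nM

Going by the values given here, compound 2, at 32600 nM, holds the only actual number in this assay. For compound 1 there is only the limit, (the limit of > 40000 nM in this assay, at which 1 of the 2 values shown sits). Among the compounds with values here, the one measured step, an at least 1.2-fold lower number from compound 1 to compound 2 (0.08 log units; that floor lies within the scatter), puts 4-methylphenyl in place of 3-methoxyphenyl on the amide-type nitrogen in a ring. Being a floor, it leaves the true size of that step open, and it concerns a different change on the same aryl group.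

Compound 3 `O=C1COc2ccc(-c3cnc(Cl)c(NS(=O)(=O)c4ccc(F)cc4)c3)cc2N1c1ccc(Cl)cc1` differs from compound 2 by chloro in place of methyl on an aromatic carbon, para to a large group, so that 4-methylphenyl becomes 4-chlorophenyl. Within the data shown here, no measured step tests this exchange directly, and the only guide is the step from compound 1 at its floor. No shift beyond the scatter is therefore expected in this assay, in either direction, and a reading at the limit remains possible. For compound 3 the estimated value is 28000 nM, with an expected range from 12000 nM to 50000 nM. The expected change is a 1.2-fold lower number from compound 2 to compound 3 (0.07 log units; within the scatter).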

Compound 3, half-maximal inhibitory concentration: 32800 nM
Estimate against measurement, compound 3: 1.2-fold (0.07 log units) below; the range from low to high includes it.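

In this assay, a 1.0-fold higher number from compound 2 to compound 3 (0.00 log units; within the scatter) gives the first direct test of chloro in place of methyl on this aromatic carbon, and it lies within the scatter, so 4-chlorophenyl and 4-methylphenyl cannot be told apart in this assay. The second step, an at least 1.2-fold lower number from compound 1 to compound 3 (0.08 log units; that floor lies within the scatter), is again only a floor within the scatter, so the comparison with 3-methoxyphenyl gains a second partner but no firmer size. Compound 1 still holds a limit and not a number: the limit of > 40000 nM in this assay, at which 1 of the 3 values shown sits.

On these data alone, what an amine or a carboxylic acid would do in the same place on this phenyl ring remains open, as does the true distance between 3-methoxyphenyl and the two 4-substituted phenyl groups. Also open, as far as these compounds go, is whether a change elsewhere on the shared core, such as an amine in place of the chloro on the core or a different group on the sulfonamide, would move the number beyond the scatter, which neither exchange on this aryl group has done.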